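The source may hold more compounds than are shown below. What is called first, only, known or untested is meant among the compounds shown, and "the series" means these compounds.

- Compound 1 `N=c1sc2cc(OC(F)(F)F)ccc2n1Cc1ccccc1`: > 10 mg/kg
- Compound 2 `N=c1sc2cc(OC(F)(F)F)ccc2n1CC(N)=O`: 7 mg/kg
- Compound 3 `N=c1sc2cc(OC(F)(F)F)ccc2n1CCO`: 8 mg/kg

These values come from a functional assay on the whole organism with Rattus norvegicus as the target; a lower number here means that less compound is needed, a higher number that more compound is needed for the effect. The value of compound 1 is a limit, not a number. Compound 3 gives 8 mg/kg, and a 1.1-fold higher number from compound 2 to compound 3 (0.06 log units; within the scatter) places it level with compound 2. Compound 4 `CCSCCn1c(=N)sc2cc(OC(F)(F)F)ccc21` has ethylsulfanyl in place of hydroxy on a saturated chain carbon, two bonds along the chain from an aromatic nitrogen. Among the compounds with values here, no measured step makes this exact swap, but the side chain has been varied before: an at least 1.2-fold lower number from compound 1 to compound 3 (0.09 log units; that floor lies within the scatter), and an at least 1.4-fold lower number from compound 1 to compound 2 (0.15 log units; that floor lies within the scatter). None of these steps clears the scatter, so no clear shift is expected in this assay. The expected change is no change at the digits printed from compound 3 to compound 4 (within the scatter). Compound 4 is estimated at 8 mg/kg, within an expected range of 4 mg/kg to 16 mg/kg.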

Compound 4, dose for half-maximal effect: 2.2 mg/kg
For compound 4 the middle estimate is 3.6-fold (0.56 log units) above the measured one; the whole stated range lies above it.
By their numbers in this assay, from the lowest: compound 4; then compounds 2 and 3 (each within the scatter of the next). At a limit, above all of these: compound 1.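

Within the data shown here, replacing hydroxy with ethylsulfanyl on this side chain moves the number in this assay beyond the scatter, which no earlier step did (a 3.6-fold lower number from compound 3 to compound 4 (0.56 log units; beyond the scatter)). The 2-(ethylsulfanyl)ethyl chain also stands clear of the carbamoyl-bearing chain (a 3.2-fold lower number from compound 2 to compound 4 (0.50 log units; beyond the scatter)) and of the phenyl-bearing chain (an at least 4.5-fold lower number from compound 1 to compound 4 (0.65 log units; beyond the scatter)). Compound 1 carries a limit, so its step is only a floor: the limit of > 10 mg/kg in this assay, at which 1 of the 4 values shown sits.

From the compounds shown here alone, whether the sulfur or the two added carbons carry this step stays open. A 2-ethoxyethyl chain, with oxygen in place of sulfur, would help separate the two, and how a 2-aminoethyl chain compares is also unknown.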